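The compounds below may be only part of what the source reports. "The series", "measured", "known", "first", "only" and "open" are said of these compounds alone.

Values measured in an ADME assay on HepG2 2.2.15 cells (Homo sapiens) for cytotoxicity (a higher number here means that more compound is tolerated, a lower number that less compound is tolerated), are these:
compound 1 `CC(=O)OCC(=O)OCCc1c(-c2ccccc2Cl)c2cc(Cl)ccc2[nH]c1=O` gives 100000 nM
compound 2 `COc1cccc(/C=C/C(=O)OCCc2c(-c3ccccc3Cl)c3cc(Cl)ccc3[nH]c2=O)c1` gives > 1300000 nM (a limit)
compound 3 `COc1ccc(/C=C/C(=O)OCCc2c(-c3ccccc3Cl)c3cc(Cl)ccc3[nH]c2=O)cc1` gives > 1200000 nM (a limit)

Compound 3 thus stands at a limit and has no number. Compound 4 `COc1ccc(/C=C/C(=O)OCCc2c(-c3ccccc3Cl)c3cc(Cl)ccc3[nH]c2=O)cc1OC` differs from it by methoxy in place of hydrogen on an aromatic carbon and so has 3,4-dimethoxyphenyl in place of 4-methoxyphenyl. The closest comparison swaps 3-methoxyphenyl for 4-methoxyphenyl, but it is a step that the two limits leave unreadable from compound 2 to compound 3 and gives no size. The large steps, an at least 13-fold higher number from compound 1 to compound 2 (1.11 log units; beyond the scatter) and an at least 12-fold higher number from compound 1 to compound 3 (1.07 log units; beyond the scatter), replace acetoxymethyl and bear only loosely on this change. No step beyond the scatter is therefore expected in this assay, and another limit is likely. The estimated step is an at least 1.2-fold lower number from compound 3 to compound 4 (0.07 log units; that floor lies within the scatter) in this reading. For compound 4 the estimated value is 1000000 nM with an expected range from 250000 nM to 1500000 nM here.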

Compound 4, half-maximal cytotoxic concentration: > 1200000 nM
Compound 4: a limit, no number; the forecaster's own chance of this, stated with the estimate: 70%; at least 1.2-fold (0.07 log units) between middle value and limit.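

Compound 4 also ends at a limit in this assay, so methoxy in place of hydrogen on this aromatic carbon yields no number: the limit of > 1200000 nM in this assay, at which 2 of the 4 values shown sit. The 2-(3,4-dimethoxyphenyl)ethenyl group thus stays as far from acetoxymethyl as the two single-methoxy groups, with an at least 12-fold higher number from compound 1 to compound 4 (1.07 log units; beyond the scatter). The steps among compound 2, compound 3 and compound 4 cannot be read, so the effect of the added methoxy has no size. On these data alone, whether an amine or a carboxylic acid in place of this methoxy would give a readable number in this assay remains open.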